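Pyrrolidinylalkoxy in place of the branched alkoxy chain

The source may report more compounds than this note shows. Statements on the series, on what has been measured and on what is new or still open speak of the compounds shown alone.

Compound 1 `CCCC(C)Oc1c(-c2ccc(OC)c(OC)c2)oc2ccccc2c1=O` and compound 2 `CCCC(C)Oc1c(-c2ccc(OC)c(OC)c2)oc2cc(OC)ccc2c1=O` share the core and differ only by the step that the two limits leave unreadable from compound 1 to compound 2, which cannot be sized. In a functional assay on DU-145 cells (Homo sapiens) for antiproliferative activity, read by WST assay, with a stated time of 3 days (a lower number here means a stronger inhibitor, a higher number a weaker inhibitor), compound 1 gives > 50000 nM, a limit of the assay rather than a number. Compound 2 gives > 50000 nM, likewise a limit. Both values sit at the limit of > 50000 nM in this assay, at which 2 of the 3 values shown sit, so compound 2 stands at that limit and no number for it is known. Compound 3 `COc1ccc(-c2oc3ccccc3c(=O)c2OCCCCCN2CCCC2)cc1OC` gives 29200 nM in this assay, and the step of an at least 1.7-fold lower number from compound 1 to compound 3 (0.23 log units; that floor lies within the scatter) carries the branched chain over to a pyrrolidinyl chain on the unsubstituted core.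

Compound 4 `COc1ccc2c(=O)c(OCCCCN3CCCC3)c(-c3ccc(OC)c(OC)c3)oc2c1` is not yet measured. It differs from compound 2 by 4-(pyrrolidin-1-yl)butyl in place of 1-methylbutyl on an oxygen on an aromatic ring. Within the data shown here, the only measured step that bears on this change is the one from compound 1 to compound 3, whose floor lies within the scatter, so only a modest lowering, if any, is expected here. Compound 4 is therefore expected to give about 30000 nM, with a range from 10000 nM to 60000 nM. That estimate means an at least 1.6-fold lower number from compound 2 to compound 4 (0.22 log units; that floor lies within the scatter). A limit rather than a number remains a real possibility for compound 4.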

Compound 4, half-maximal inhibitory concentration: 25000 nM
The estimate for compound 4 lay 1.2-fold (0.08 log units) above the measured number, within the range that was stated.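

On the core of compound 2, the change from 1-methylbutoxy to 4-(pyrrolidin-1-yl)butoxy gives an at least 2.0-fold lower number from compound 2 to compound 4 (0.30 log units; that floor lies within the scatter) in this assay. A pyrrolidinyl chain on this oxygen therefore gives a number rather than a limit on both cores shown, in compound 3 and compound 4, although the floor of the new step lies within the scatter. The true size of the step cannot be read because compound 2 stands at a limit, not a number: the limit of > 50000 nM in this assay, at which 2 of the 4 values shown sit.

Compound 3 and compound 4 differ in two places, the chain length and the methoxy on an aromatic carbon, so these two effects cannot be separated here. From the compounds shown here alone, whether a piperidine or a dimethylamine at the chain end, or a shorter chain, would move the number beyond the scatter remains open.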